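Methoxy added to compound 2: expected step

This account rests on a few compounds, and the source may have more. Where it says the series, first, only, none or still open, it means among the compounds named here.

In a functional assay on HeLa cells (Homo sapiens) for antiproliferative activity, read by sulforhodamine B assay, with a stated time of 48 h (a lower number here means a stronger inhibitor, a higher number a weaker inhibitor), compound 2 `COc1cc(OC)c2sc(-c3ccc(N/C=C\C(=O)c4cc(OC)c(OC)c(OC)c4Br)c(C)c3)nc2c1` gives 14700 nM and stands within the scatter of compound 3 `COc1cc(OC)c2sc(-c3ccc(N/C=C\C(=O)c4cc(OC)c(OC)c(OC)c4)c(C)c3)nc2c1` at 16400 nM as measured. Compound 1 `COc1cc(C(=O)/C=C\Nc2ccc(-c3nc4cc(OC)c(OC)c(OC)c4s3)cc2)c(Br)c(OC)c1OC` gives 6600 nM as a lower number, beyond the scatter from compound 2.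

The change leading to compound 4 `COc1cc(C(=O)/C=C\Nc2ccc(-c3nc4cc(OC)c(OC)c(OC)c4s3)cc2C)c(Br)c(OC)c1OC` is methoxy in place of hydrogen on an aromatic carbon and nothing else. Within the data shown here, the one measured single-place step, a 1.1-fold higher number from compound 2 to compound 3 (0.05 log units; within the scatter), replaces a bromo and not this hydrogen, so it bears only loosely: it shows a change elsewhere in the molecule staying within the scatter. Among the measured compounds shown here, no measured step isolates the methoxy. Compound 1 already carries this methoxy but lacks the methyl group of compound 2 and compound 4, and compound 1 at 6600 nM therefore hints at a modest move toward a lower number. The expected change is a 1.3-fold lower number from compound 2 to compound 4 (0.13 log units; within the scatter) and no move beyond the scatter is expected. In this assay compound 4 is estimated at 11000 nM with an expected range from 5000 nM to 20000 nM as the likely span.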

Compound 4, half-maximal inhibitory concentration: 14300 nM
Compound 4: the middle estimate sits 1.3-fold (0.11 log units) below what was measured, within the range that was stated.
By their numbers in this assay, from the lowest: compound 1; then compounds 4, 2 and 3 (each within the scatter of the next).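

In this assay methoxy in place of hydrogen on this aromatic carbon, ortho to two methoxy groups, stays within the scatter (a 1.0-fold lower number from compound 2 to compound 4 (0.01 log units; within the scatter)), so the compounds shown give this position no measurable response to the change. With the methoxy present in both compounds, the methyl group alone separates compound 1 from compound 4, and that step lies beyond the scatter (a 2.2-fold higher number from compound 1 to compound 4 (0.34 log units; beyond the scatter)), which ties the lower number of compound 1 to the absence of the methyl group rather than to this methoxy. No supporting measurement bears on why either step has the size it has.

At this carbon the compounds shown carry only hydrogen or methoxy, so an amine or a carboxylic acid there remains open. Also open, as far as these compounds go, is whether the methoxy would stay within the scatter in a compound without the methyl group.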